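Bromophenyl replaces fluorophenyl on the shared core

This account rests on a few compounds, and the source may have more. Where it says the series, first, only, none or still open, it means among the compounds named here.

For the measured compounds named here, compound 2 `O=c1c2ccccc2[se]n1-c1nnc(-c2ccc(F)cc2)s1` gives 42900 nM in a functional assay on SSMC-7721 cells (Homo sapiens) for antiproliferative activity, read by CCK-8 assay, with a stated time of 48 h (on this read-out lower numbers stand for stronger inhibition and higher numbers for weaker inhibition), the higher of the two numbers measured so far; compound 1 `COc1ccc(-c2nnc(-n3[se]c4ccccc4c3=O)s2)cc1` gives 16500 nM. Going by the values given here, the only measured step, a 2.6-fold higher number from compound 1 to compound 2 (0.41 log units; beyond the scatter), is modest and swaps one substituent for another on the same aromatic ring. Compound 3 `O=c1c2ccccc2[se]n1-c1nnc(-c2ccccc2Br)s1` differs from compound 2 by 2-bromophenyl in place of 4-fluorophenyl on an aromatic carbon. Among the compounds with values here, no measured step covers this change, so nothing beyond the scatter is expected for compound 3, whose step a 1.2-fold lower number from compound 2 to compound 3 (0.09 log units; within the scatter) is estimated as small. Compound 3 is therefore estimated at 35000 nM, in a range from 12000 nM to 100000 nM.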

Compound 3, half-maximal inhibitory concentration: 27400 nM
Beside the measured number, compound 3's estimate is 1.3-fold (0.11 log units) above it, within the range that was stated.
By their numbers in this assay, from the lowest: compounds 1, 3 and 2 (each within the scatter of the next, the first and the last beyond it).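

In this assay, the step of a 1.6-fold lower number from compound 2 to compound 3 (0.19 log units; within the scatter) lies within the scatter, so at this position 2-bromophenyl and 4-fluorophenyl cannot be told apart. The earlier step, a swap of fluoro for methoxy on the phenyl ring, lay beyond the scatter, whereas this exchange of the whole substituted phenyl group, with both the halogen and its ring position changed, does not. The compounds shown leave open whether a phenyl ring bearing an amine or a carboxylic acid would give a number beyond the scatter, and no measured evidence bears on this result.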